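A few compounds are considered here, and "the series" means these few. Any claim that something is new, unique, unknown or untested is made for them only; others in the source may bear on it.

Working notes on the series. In a functional assay on HCT-15 cells (Homo sapiens) for antiproliferative activity, read by sulforhodamine B assay (on this read-out lower numbers stand for stronger inhibition of growth and higher numbers for weaker inhibition of growth), compound 1 `CC(C)C1CC(=O)c2s/c(=N/c3ccc(F)cc3)oc2C1` gives 2990 nM. Compound 2 `CC1(C)CC(=O)c2s/c(=N/c3c(Cl)cc(Cl)cc3Cl)oc2C1` is reported in this assay only as a limit, > 30000 nM, which is not a number. Compound 2 thus stands at the limit of > 30000 nM in this assay, at which 1 of the 2 values shown sits, the weaker end of the two values shown. Compound 3 `CC1CC(=O)c2s/c(=N/c3c(Cl)cc(Cl)cc3Cl)oc2C1` is not yet measured. It differs from compound 2 by hydrogen in place of methyl on a saturated ring carbon. Among the compounds with values here, no step between measured compounds is known, so no direction can be drawn from the measured pair. Compound 3 is expected near 25000 nM, within 5000 nM to 100000 nM. The expected step of an at least 1.2-fold lower number from compound 2 to compound 3 (0.07 log units; that floor lies within the scatter) is therefore estimated as small, not clearly beyond the scatter.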

Compound 3, concentration for 50% growth inhibition: > 30000 nM
Compound 3 was reported as a limit; the forecaster's own chance of this, stated with the estimate: 55%; middle value at least 1.2-fold (0.07 log units) from the limit.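

Within the data shown here, compound 2 and compound 3 are both reported only as limits, so no step between them can be read: the limit of > 30000 nM in this assay, at which 2 of the 3 values shown sit. The compounds shown leave open whether hydrogen in place of methyl on a saturated ring carbon changes the result in this assay.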